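Solubility expectation for a new amide variant of compound 1

The source may hold more compounds than are shown below. What is called first, only, known or untested is meant among the compounds shown, and "the series" means these compounds.

Going by the values given here, compound 1 `C[C@]1(c2ccc(F)cc2F)C[C@H](COc2ccc(N3CCN(c4ccc(-n5cnn(CCCO)c5=O)cc4)CC3)cc2)CO1` is one of two compounds measured so far in a physicochemical assay for solubility, read by LC-MS, in phosphate buffer, measured as kinetic solubility, at pH 7.4 (a lower number here means a less soluble compound, a higher number a more soluble compound), where compound 1 gives 1560 nM. The other, compound 2 `CC1(c2ccc(Cl)cc2Cl)OCC(COc2ccc(N3CCN(c4ccc(-n5cnn(CCC(=O)O)c5=O)cc4)CC3)cc2)O1`, gives 781 nM in this assay, and the two numbers lie within the usual scatter of each other. Compound 3 `CC(=O)c1cccc(C(=O)Nc2ccc(N3CCN(c4ccc(OC[C@@H]5CO[C@@](C)(c6ccc(F)cc6F)C5)cc4)CC3)cc2)c1` has not yet been measured; it differs from compound 1 in one place: a group of 12 heavy atoms (9 carbon, 1 nitrogen, 2 oxygen; one six-membered aromatic ring of carbon only) in place of a group of 10 heavy atoms (5 carbon, 3 nitrogen, 2 oxygen; one five-membered aromatic ring with 3 hetero atoms), on an aromatic carbon. Among the compounds with values here, no step between measured compounds exists to calibrate this change, so the expectation rests on the structural change alone. Compound 3 is expected to come out lower, by a step of a 3.1-fold lower number from compound 1 to compound 3 (0.49 log units; beyond the scatter) that goes somewhat beyond the scatter, at about 500 nM with a range from 150 nM to 2000 nM.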

Compound 3, solubility: 3130 nM
Compound 3: middle estimate off by 6.3-fold (0.80 log units), on the low side, and the stated range ends below it.
By their numbers in this assay, from the lowest: compounds 2, 1 and 3 (each within the scatter of the next, the first and the last beyond it).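

Putting ((3-acetylphenyl)carbonyl)amino in place of the group with a five-membered aromatic ring with 3 hetero atoms, on an aromatic carbon para to a large group, gives a 2.0-fold higher number from compound 1 to compound 3 (0.30 log units; within the scatter) in this assay. This is the first step shown at this position, and even this exchange of ring type stays within the scatter. Nothing measured here explains the result.

Still open, from the compounds shown here alone, is how the reading would change with an amine or a nitrile in place of the acetyl group. A single step also cannot show whether the same exchange would stay within the scatter on a different core.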